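Stereochemical variation in a polyhydroxylated pipecolic acid series

The compounds below may be only part of what the source reports. "The series", "measured", "known", "first", "only" and "open" are said of these compounds alone.

Two members of the series have been measured in an assay for inhibition of alpha-N-acetylgalactosaminidase (Gallus gallus), tested at 1000 uM; a lower number here means less inhibition, a higher number more inhibition at the concentration tested (going by the name of the read-out). Compound 1 `O=C(O)[C@@H]1NCC=C[C@@H]1O` gives a low number under these conditions: in this assay compound 1 gives 1.3%. Compound 2 `O=C(O)[C@H]1NC[C@H](O)[C@H](O)[C@H]1O` carries three ring hydroxyls on the saturated core, and in this assay compound 2 gives 21%. Of the two numbers, compound 2 stands highest, and its gap to compound 1 lies beyond the usual scatter of the measurement.

Compound 3 `O=C(O)[C@H]1NC[C@@H](O)[C@H](O)[C@@H]1O` has not yet been measured. It shares every atom and bond with compound 2; the difference is the two compounds have the same atoms and bonds and differ only in configuration as drawn: 2 of 4 stereo elements differ; a stereocentre at a saturated ring carbon is drawn S in compound 2 and R in compound 3; a stereocentre at a saturated ring carbon is drawn S in compound 2 and R in compound 3. Within the data shown here, no step between two measured compounds touches configuration alone, so there is no measured precedent for what a change of this kind does in this assay.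

For a change at two ring stereocentres the expected step is a decrease in this assay, of moderate size, with a real chance that it falls within the scatter: the expected step from compound 2 to compound 3 is a number 9 percentage points lower from compound 2 to compound 3 (within the scatter). On that basis compound 3 is estimated at 12%, in the range 0% to 45%.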

Compound 3, a percentage reported as inhibition, at one concentration (the size of the read-out at that concentration, not a potency): 11%
For compound 3 the middle estimate is 1 percentage points above the measured one, within the range that was stated.
By their numbers in this assay, from the lowest: compounds 1, 3 and 2 (each within the scatter of the next, the first and the last beyond it).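

Among these compounds, this is the first measured step that touches configuration alone, and in this assay it reads a number 10 percentage points lower from compound 2 to compound 3 (within the scatter). Redrawing two saturated ring stereocentres from S to R therefore gives no change beyond the scatter, so compound 2 and compound 3 cannot be ranked, and this pair gives no sign that the read-out depends on the configuration at these two stereocentres. Any reading of this step concerns stereochemistry and nothing else, with no group entering or leaving: the fact that compounds 2 and 3 differ only in the configuration as drawn

On these data alone, both stereocentres change together in this pair, so the contribution of each one alone remains open, as does whether opposing effects could sit behind the small net step. Also open, as far as these compounds go, is whether replacing the carboxylic acid with a methyl ester, or a ring hydroxyl with an acetamido group, would move the number in this assay beyond the scatter on either configuration of the shared core.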